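The compounds below may be only part of what the source reports. "The series", "measured", "known", "first", "only" and "open" are said of these compounds alone.

Measured so far in a functional assay on MCF7 cells (Homo sapiens) for antiproliferative activity, read by MTT assay, with a stated time of 48 h, tested at 12.5 uM; a lower number here means a stronger effect, a higher number a weaker effect of the compound at the concentration tested:

compound 1 `OC(CCn1nc2c(Br)c(Br)c(Br)c(Br)c2n1)c1cccc(Cl)c1`: 107%
compound 2 `C[C@@H](O)CCn1nc2c(Br)c(Br)c(Br)c(Br)c2n1`: 86%
compound 3 `OC(CCn1nc2c(Br)c(Br)c(Br)c(Br)c2n1)c1ccc(Br)cc1`: 107%

Compound 1 is level with compound 3 at the digits shown, the two together the highest of the three numbers; compound 2 lies lower, beyond the scatter. Going by the values given here, the single measured step, no change at the digits printed from compound 1 to compound 3 (within the scatter), exchanges one aromatic group for another and therefore says nothing about the change in question.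

Compound 4 `CC(O)CCn1nc2c(Br)c(Br)c(Br)c(Br)c2n1` differs from compound 1 by methyl in place of 3-chlorophenyl on a saturated chain carbon bound to an oxygen on a saturated carbon and a saturated chain carbon. Among the compounds with values here, no measured step covers this exchange. What bears on it is that compound 2, which carries a methyl on the same saturated chain carbon, gives 86%, whereas compound 1 gives 107%. A downward step of about that gap is expected, a number 19 percentage points lower from compound 1 to compound 4 (beyond the scatter). Compound 4 is estimated at 88%, with a range from 70% to 106%.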

Compound 4, a percentage reported as activity, at one concentration (the size of the read-out at that concentration, not a potency): 79%
Beside the measured number, compound 4's estimate is 9 percentage points above it; measured number inside the range.
By their numbers in this assay, from the lowest: compounds 4 and 2 (each within the scatter of the next); then compounds 1 and 3 (each within the scatter of the next).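

In this assay the earlier exchange of one aromatic group for another left no mark, whereas methyl in place of the aromatic group on this carbon does: a number 28 percentage points lower from compound 1 to compound 4 (beyond the scatter) and a number 28 percentage points lower from compound 3 to compound 4 (beyond the scatter) are both steps towards a stronger effect. With a number 7 percentage points lower from compound 2 to compound 4 (within the scatter) the two methyl compounds show no separable difference, and this comparison concerns a single stereo element: the fact that one of compounds 2 and 4 is drawn with a defined configuration and the other without, at the place where they differ.

Still open, on these data alone, is whether an ethyl, a longer chain or a cyclohexyl on the same saturated chain carbon reads with methyl or with the aromatic groups. Also open, as far as these compounds go, is what a compound drawn S at this stereocentre gives.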